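The source may report more compounds than this note shows. Statements on the series, on what has been measured and on what is new or still open speak of the compounds shown alone.

Series notes. Within the data shown here, in a functional assay on BJAB cells (Homo sapiens) for antiproliferative activity, with a stated time of 4 days (on this read-out lower numbers stand for an effect already at smaller amounts and higher numbers for an effect only at larger amounts of compound), compound 3 `Cc1nn(-c2nc(-c3ccc(Cl)c(Cl)c3)c(SC(C)C)s2)c(C(=O)O)c1-c1cccc(Cl)c1C` gives 5100 nM, the highest of the three numbers measured so far. Compound 1 `COc1cc(-c2c(C)nn(-c3nc(-c4ccc(Cl)c(Cl)c4)c(SC(C)C)s3)c2C(=O)O)cc(C(F)(F)F)c1` gives 1380 nM and compound 2 `Cc1nn(-c2nc(-c3ccc(Cl)c(Cl)c3)c(SC(C)C)s2)c(C(=O)O)c1-c1ccc(Cl)cc1` gives 2500 nM in this assay. Compound 4 `Cc1cc(-c2c(C)nn(-c3nc(-c4ccc(Cl)c(Cl)c4)c(SC(C)C)s3)c2C(=O)O)cc(C)n1` is not yet measured; it differs from compound 3 by 2,6-dimethylpyridin-4-yl in place of 3-chloro-2-methylphenyl on an aromatic carbon. Among the measured compounds shown here, the steps that bear on this change are the earlier aryl exchanges on the same aromatic carbon: a 3.7-fold higher number from compound 1 to compound 3 (0.57 log units; beyond the scatter) and a 2.0-fold higher number from compound 2 to compound 3 (0.31 log units; beyond the scatter), alongside a 1.8-fold higher number from compound 1 to compound 2 (0.26 log units; within the scatter). Such exchanges have so far moved this assay by no more than a modest amount, and both other aryls gave lower numbers than compound 3, so for compound 4 a modest lowering is expected, a 1.7-fold lower number from compound 3 to compound 4 (0.23 log units; within the scatter). The estimate for compound 4 in this assay is 3000 nM, with a range of 1200 nM to 8000 nM.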

Compound 4, half-maximal effective concentration: 580 nM
Compound 4: the middle estimate sits 5.2-fold (0.71 log units) above what was measured; the whole stated range lies above it.
By their numbers in this assay, from the lowest: compound 4; then compounds 1 and 2 (each within the scatter of the next); then compound 3.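

On the aromatic carbon of the shared core, 2,6-dimethylpyridin-4-yl is the only aryl shown with a ring nitrogen, and in this assay it gives the lowest number of the four: an 8.8-fold lower number from compound 3 to compound 4 (0.94 log units; beyond the scatter) and a 4.3-fold lower number from compound 2 to compound 4 (0.63 log units; beyond the scatter) and also a 2.4-fold lower number from compound 1 to compound 4 (0.38 log units; beyond the scatter) with all three steps beyond the scatter. The largest exchange among the earlier aryls was a 3.7-fold higher number from compound 1 to compound 3 (0.57 log units; beyond the scatter) so this position allows a wider span than they showed. No measurement here accounts for the change.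

The compounds shown do not separate the ring nitrogen from the two methyl groups. An unsubstituted pyridine ring or a dimethylphenyl group on the same carbon would part the two.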